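This account rests on a few compounds, and the source may have more. Where it says the series, first, only, none or still open, it means among the compounds named here.

Compound 2, `COc1cc(N)c(Cl)cc1C(=O)NC1CCN(CCCCCCCCN2CCCCC2)CC1`, and compound 1, `COc1cc(N)c(Cl)cc1C(=O)NC1CCN(CCCCCN2C(=O)c3ccccc3C2=O)CC1`, share the same core and differ only at the far end of the chain on the ring amine. In a functional assay on HEK293 cells for agonist activity at 5-hydroxytryptamine receptor 4 (Homo sapiens), read by cAMP accumulation (a lower number here means that less compound is needed, a higher number that more compound is needed for the effect), compound 2 gives 3.16 nM, and compound 1 gives 5.01 nM; the two numbers stand within the scatter of each other, so neither compound is separated from the other, and compound 2 simply holds one of two close values. The step of a 1.6-fold lower number from compound 1 to compound 2 (0.20 log units; within the scatter) shows that a large change at this chain end left the read-out essentially unchanged.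

Compound 3, `COc1cc(N)c(Cl)cc1C(=O)NC1CCN(CCCCCN2CCN(S(C)(=O)=O)CC2)CC1`, is not yet measured. Its change from compound 2 is 4-(methylsulfonyl)piperazin-1-yl in place of 3-(piperidin-1-yl)propyl on a saturated chain carbon, five bonds along the chain from an amine nitrogen in a ring. Within the data shown here, the only step that bears on this place is the one from compound 1 to compound 2, which was within the scatter, so the expectation for this assay is again no step beyond the scatter: the step from compound 2 to compound 3 is estimated at a 1.3-fold higher number from compound 2 to compound 3 (0.10 log units; within the scatter). Compound 3 is therefore expected to give about 4 nM, in a range from 1.3 nM to 12 nM.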

Compound 3, half-maximal effective concentration: 12.6 nM
For compound 3 the middle estimate is 3.2-fold (0.50 log units) below the measured one; the measured number lies above the stated range.
By their numbers in this assay, from the lowest: compounds 2 and 1 (each within the scatter of the next); then compound 3.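

In this assay, this chain end does not tolerate every change equally: there is a 4.0-fold higher number from compound 2 to compound 3 (0.60 log units; beyond the scatter), and a 2.5-fold higher number from compound 1 to compound 3 (0.40 log units; beyond the scatter), both modest, whereas the earlier step between compound 1 and compound 2 stayed within the scatter. Among these compounds, the 4-(methylsulfonyl)piperazin-1-yl group of compound 3 is thus the first end group here to separate from the others, and more of the compound is needed for the effect. No measurement shown here accounts for this shift.

The compounds shown leave open whether the higher number goes with the methylsulfonyl group or with the piperazine ring itself, a question that a plain piperazine or an acetyl group on that ring could address. They also leave open how a longer chain carrying the same 4-(methylsulfonyl)piperazin-1-yl group would read in this assay.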